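The source may hold more compounds than are shown below. What is called first, only, known or untested is meant among the compounds shown, and "the series" means these compounds.

Compound 3 `CCCS(=O)(=O)Nc1ccc(F)c(C(=O)c2n[nH]c3ncc(-c4ccc(Cl)c(Cl)c4)cc23)c1F` carries a 3,4-dichlorophenyl group on the shared core. In an assay for binding affinity to dual specificity mitogen-activated protein kinase kinase 4 (Homo sapiens), read by KINOMEscan, tested at 100 nM (on this read-out lower numbers stand for a stronger effect and higher numbers for a weaker effect at the one concentration tested), compound 3 gives 45%, the highest of the three numbers measured. Compound 1 `CCCS(=O)(=O)Nc1ccc(F)c(C(=O)c2n[nH]c3ncc(-c4ccccc4OC)cc23)c1F` gives 1.9% in this assay, and compound 2 `CCCS(=O)(=O)Nc1ccc(F)c(C(=O)c2n[nH]c3ncc(-c4cccc(N)c4)cc23)c1F` gives 1.6%; the two lie within the scatter of each other, as a number 0.3 percentage points lower from compound 1 to compound 2 (within the scatter) shows. Compound 4 `CCCS(=O)(=O)Nc1ccc(F)c(C(=O)c2n[nH]c3ncc(-c4cccc([N+](=O)[O-])c4)cc23)c1F` is not yet measured. It differs from compound 3 in one place: 3-nitrophenyl in place of 3,4-dichlorophenyl on an aromatic carbon.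

Among the compounds with values here, the steps that bear on this change are those leading into compound 3, namely a number 43.1 percentage points higher from compound 1 to compound 3 (beyond the scatter) and a number 43.4 percentage points higher from compound 2 to compound 3 (beyond the scatter). Both show that exchanging another phenyl group for the 3,4-dichlorophenyl raised the number by a large amount. On these data alone, the 3-nitrophenyl group itself has not been seen in any measured compound, so its own level is unknown. Because compound 1 gives 1.9% and compound 2 gives 1.6% without the 3,4-dichlorophenyl, compound 4 is expected to fall back toward those lower numbers, a step of a number 30 percentage points lower from compound 3 to compound 4 (beyond the scatter). Compound 4 is therefore estimated to give 15% in this assay, between 2% and 50%.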

Compound 4, a percentage reported as activity, at one concentration (the size of the read-out at that concentration, not a potency): 15%
Compound 4: middle estimate and measured number agree at the digits printed; low and high end bracket the measured number.
By their numbers in this assay, from the lowest: compounds 2 and 1 (each within the scatter of the next); then compound 4; then compound 3.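

Within this assay, replacing the 3,4-dichlorophenyl with 3-nitrophenyl gives a number 30 percentage points lower from compound 3 to compound 4 (beyond the scatter) and so recovers part of the rise seen with that group. The recovery is incomplete: exchanging amino for nitro on the same phenyl ring gives a number 13.4 percentage points higher from compound 2 to compound 4 (beyond the scatter), and the step from the 2-methoxyphenyl gives a number 13.1 percentage points higher from compound 1 to compound 4 (beyond the scatter), so compound 4 forms a third level among the compounds at this position, and the substituent on a nitrogen-free phenyl ring is shown to grade the number rather than simply switch it between low and high. No measurement shown gives a reason for these steps.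

The compounds shown leave open whether a single chlorine on the phenyl ring would give a number nearer that of compound 3 or that of compound 4. They also leave open where a carboxylic acid or a methylamino group in place of the nitro would fall.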